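A few compounds are considered here, and "the series" means these few. Any claim that something is new, unique, unknown or untested is made for them only; others in the source may bear on it.

Notes on the series. Compound 1 `Cc1cnc(Nc2ccc(Cl)cc2)nc1Nc1nc2ccccc2s1` carries a chloro group on its aryl ring; in a functional assay on MCF7 cells (Homo sapiens) for antiproliferative activity, read by MTT assay, with a stated time of 48 h (on this read-out lower numbers stand for stronger inhibition and higher numbers for weaker inhibition), compound 1 gives only a limit, > 50000 nM. Compound 2 `Cc1cnc(Nc2ccc(S(N)(=O)=O)cc2)nc1Nc1nc2ccccc2s1` has sulfamoyl in place of chloro on an aromatic carbon, and in this assay compound 2 likewise gives only a limit, > 50000 nM. The step that the two limits leave unreadable from compound 1 to compound 2 is therefore unreadable. Compound 3 `NS(=O)(=O)c1ccc(Nc2nccc(Nc3nc4ccccc4s3)n2)cc1` has hydrogen in place of methyl on an aromatic carbon and gives 15300 nM in this assay, a step of an at least 3.2-fold lower number from compound 2 to compound 3 (0.51 log units; beyond the scatter). Two of the three values shown sit at the limit of > 50000 nM in this assay, at which 2 of the 3 values shown sit, so compound 2 stands at the limit, with nothing measurable beneath it.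

Compound 4 `Cc1cnc(Nc2ccc(S(N)(=O)=O)cc2)nc1Nc1nc2ccc(F)cc2s1` differs from compound 2 as fluoro in place of hydrogen on an aromatic carbon. Going by the values given here, neither measured step touches the fused two-ring system, so no measured step bears on this change. A single fluorine is not expected to move a value that already sits at the limit; the expected step is a step that the limit leaves unreadable from compound 2 to compound 4. Compound 4 is therefore estimated at 60000 nM, between 20000 nM and 200000 nM, most probably reported again as a limit.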

Compound 4, half-maximal inhibitory concentration: > 50000 nM
Compound 4: no number, only a limit; the forecaster's own chance of this, stated with the estimate: 70%; the middle value is on the limit's open side.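

In this assay compound 4 gives > 50000 nM, which is a limit and not a number. Going by these compounds alone, no step between compound 2 and compound 4 can be read, as both compounds give only limits: the limit of > 50000 nM in this assay, at which 3 of the 4 values shown sit. The compounds shown leave open whether fluoro in place of hydrogen changes the value at all where this assay gives a number.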